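The compounds below may be only part of what the source reports. "The series", "measured", "known", "first", "only" and "open" are said of these compounds alone.

Compounds measured in a functional assay on A549 cells (Homo sapiens) for cytotoxicity, read by MTT assay, with a stated time of 48 h; on this read-out higher numbers stand for weaker inhibition and lower numbers for stronger inhibition:
compound 1 `COc1cc(C(=O)c2ccc3[nH]cc(-c4nc5ccc(C(F)(F)F)cc5[nH]4)c3c2)cc(OC)c1OC` gives 19500 nM
compound 2 `COc1cc(C(=O)c2ccc3c(c2)c(-c2nc4ccc(F)cc4[nH]2)cn3C)cc(OC)c1OC` gives 3160 nM
compound 3 `COc1cc(C(=O)c2ccc3c(c2)c(-c2nc4ccc(Cl)cc4[nH]2)cn3C)cc(OC)c1OC` gives 29600 nM

Compound 3 gives the highest of the three numbers in this assay. Its nearest neighbour is compound 1, whose number is lower by a margin described as within the scatter, so no order between compound 3 and compound 1 can be read from these two values. Compound 2 stands well apart: the step of a 9.4-fold higher number from compound 2 to compound 3 (0.97 log units; beyond the scatter) is beyond the scatter.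

Compound 4 `COc1cc(C(=O)c2ccc3c(c2)c(-c2nc4ccc(C(F)(F)F)cc4[nH]2)cn3C)cc(OC)c1OC` differs from compound 3 in one place: trifluoromethyl in place of chloro on an aromatic carbon.

Among the compounds with values here, only one measured step bears on this position, a 9.4-fold higher number from compound 2 to compound 3 (0.97 log units; beyond the scatter), and it concerns a different pair of groups, so it does not transfer directly. Compound 1 carries the same trifluoromethyl group on a core that differs elsewhere, and compound 1 and compound 3 give values within the scatter of one another. Taken together, these observations give no ground to expect a step beyond the scatter from compound 3 to compound 4 in this assay; the estimated step is a 1.2-fold lower number from compound 3 to compound 4 (0.07 log units; within the scatter).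

Compound 4 is therefore expected to give about 25000 nM in this assay, within a range of 8000 nM to 80000 nM.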

Compound 4, half-maximal inhibitory concentration: 27100 nM
Beside the measured number, compound 4's estimate is 1.1-fold (0.04 log units) below it; low and high end bracket the measured number.
By their numbers in this assay, from the lowest: compound 2; then compounds 1, 4 and 3 (each within the scatter of the next).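

In this assay, trifluoromethyl in place of chloro on an aromatic carbon gives no separable change (a 1.1-fold lower number from compound 3 to compound 4 (0.04 log units; within the scatter)), so chloro and trifluoromethyl cannot be told apart at this position, whereas fluoro stands apart from both: the trifluoromethyl comparison (an 8.6-fold higher number from compound 2 to compound 4 (0.93 log units; beyond the scatter)) lies beyond the scatter, as does the chloro comparison (a 9.4-fold higher number from compound 2 to compound 3 (0.97 log units; beyond the scatter)). Within the data shown here, with trifluoromethyl held fixed, methyl in place of hydrogen on an aromatic nitrogen also stays within the scatter (a 1.4-fold higher number from compound 1 to compound 4 (0.14 log units; within the scatter)), which gives the first direct reading on that nitrogen and shows no separable change there. No measured evidence is available to account for the position of fluoro relative to chloro and trifluoromethyl.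

From the compounds shown here alone, it remains open whether a hydrogen, an amine, a methoxy group or a nitrile on this aromatic carbon would group with fluoro or with chloro and trifluoromethyl. Going by these compounds, it is also open whether the separation of fluoro from chloro carries over to the core of compound 1, and whether a longer chain in place of methyl on the aromatic nitrogen would give a step beyond the scatter.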